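This account rests on a few compounds, and the source may have more. Where it says the series, first, only, none or still open, it means among the compounds named here.

In an in vivo ADME assay on the whole organism (plasma, strain Sprague-Dawley) for pharmacokinetics, with Rattus norvegicus as the target, at a dose of 1 mg/kg by the intravenous route (on this read-out higher numbers stand for fast clearance and lower numbers for slow clearance), compound 3 (`COc1cc(C(=O)N2[C@@H](c3nccs3)[C@H](CO)C[C@@]2(CC(C)C)C(=O)O)ccc1C(C)(C)C`) gives 39 mL/min/kg. This sits level with compound 1 (`COc1cc(C(=O)N2[C@@H](c3nccs3)[C@@H](C(N)=O)C[C@@]2(CC(C)C)C(=O)O)ccc1C(C)(C)C`), which gives 37 mL/min/kg, and well apart from compound 2 (`COC[C@H]1C[C@@](CC(C)C)(C(=O)O)N(C(=O)c2ccc(C(C)(C)C)c(OC)c2)[C@H]1c1nccs1`), which gives 5 mL/min/kg.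

Compound 4 (`COc1cc(C(=O)N2[C@@H](c3nccs3)[C@@H](CO)C[C@@]2(CC(C)C)C(=O)O)ccc1C(C)(C)C`) departs from compound 3 by a single change: the two compounds have the same atoms and bonds and differ only in configuration as drawn: 1 of 3 stereo elements differ; a stereocentre at a saturated ring carbon is drawn R in compound 3 and S in compound 4. Nothing leaves and nothing enters. For the measured compounds named here, the only measured step between compounds differing in one place is a 7.4-fold lower number from compound 1 to compound 2 (0.87 log units; beyond the scatter), with methoxymethyl in place of carbamoyl on a saturated ring carbon. That step exchanges a group rather than a configuration, so it bears on this change only indirectly, showing that a change at such a carbon can move the number beyond the scatter. Going by the values given here, no measured pair isolates a change of configuration, so the data give no direct size for one.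

As drawn, compound 4 shares its arrangement at this carbon with compound 1 at 37 mL/min/kg and compound 2 at 5 mL/min/kg, so that arrangement alone does not settle the number. A slight lean to the lower side is expected, with a wide margin. The expected step is a 1.6-fold lower number from compound 3 to compound 4 (0.19 log units; within the scatter). For compound 4 the estimated clearance is 25 mL/min/kg, with an expected range of 10 mL/min/kg to 55 mL/min/kg.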

Compound 4, clearance: 36 mL/min/kg
Beside the measured number, compound 4's estimate is 1.4-fold (0.16 log units) below it, and the stated range covers the measured number.
By their numbers in this assay, from the lowest: compound 2; then compounds 4, 1 and 3 (each within the scatter of the next).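

In this assay, the configuration at the saturated ring carbon now has a first measured step, a 1.1-fold lower number from compound 3 to compound 4 (0.03 log units; within the scatter), and this step can be read as one of configuration alone because of how the pair is related: the fact that compounds 3 and 4 differ only in the configuration as drawn. With the configuration of compound 4 held, hydroxymethyl in place of carbamoyl gives a 1.0-fold lower number from compound 1 to compound 4 (0.01 log units; within the scatter), while hydrogen in place of methyl on the oxygen gives a 7.2-fold higher number from compound 2 to compound 4 (0.86 log units; beyond the scatter). Among these four compounds, the steps beyond the scatter all involve compound 2, so the methyl on that oxygen separates the series here, whereas the carbamoyl-to-hydroxymethyl exchange and the change of configuration do not.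

As far as these compounds go, it remains open whether methoxymethyl keeps compound 2's low number when drawn in the configuration of compound 3, and no measurement here shows how the methyl on that oxygen goes with that number. Also open, from the compounds shown here alone, is whether a longer ether such as ethoxymethyl, or an amine such as aminomethyl, on this carbon would fall with compound 2 or with compounds 1, 3 and 4.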